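A few compounds are considered here, and "the series" means these few. Any claim that something is new, unique, unknown or untested is made for them only; others in the source may bear on it.

Compound 1 `CC(C)(C)OC(=O)N1CCC(O[C@H]2CC[C@@H](Oc3ccc(S(C)(=O)=O)cc3)CC2)CC1`, compound 2 `CC(C)OC(=O)N1CCC(O[C@H]2CC[C@H](Oc3ccc(S(C)(=O)=O)nc3)CC2)CC1` and compound 3 `CC(C)OC(=O)N1CCC(O[C@H]2CC[C@H](Oc3cnc(S(C)(=O)=O)cn3)CC2)CC1` share one core and differ at the aromatic end. In a functional assay on isolated protein for agonist activity at Glucose-dependent insulinotropic receptor (Rattus norvegicus), read by HTRF and cAMP accumulation (a higher number here means a larger maximal response, a lower number a smaller maximal response), compound 1 gives 121%, compound 2 gives 125% and compound 3 gives 120%. Going by the values given here, compound 3 therefore sits alongside the other two, within the scatter of both, and the single step recorded, a number 5 percentage points lower from compound 2 to compound 3 (within the scatter), stays within that scatter as well. Compound 4 `CS(=O)(=O)c1cnc(O[C@H]2CC[C@H](OC3CCN(C(=O)OC4CCOC4)CC3)CC2)cn1` keeps the aromatic end of compound 3 and is altered on an oxygen next to a carbonyl group: oxolan-3-yl in place of isopropyl on an oxygen next to a carbonyl group. Among the compounds with values here, no measured step bears on this place; the only recorded step concerns the aromatic end and was small. With no measured change at the oxygen next to the carbonyl group, a step beyond the scatter is not expected, and the change from compound 3 to compound 4 is estimated as no change at the digits printed from compound 3 to compound 4 (within the scatter). Compound 4 is therefore expected to give about 120% in this assay, between 105% and 135%.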

Compound 4, largest response reached (Emax), in percent of the reference or control that the assay uses: 109%
Compound 4: the middle estimate sits 11 percentage points above what was measured, within the range that was stated.
By their numbers in this assay, from the lowest: compound 4; then compounds 3, 1 and 2 (each within the scatter of the next).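

Going by these compounds alone, the earlier compounds differed only at the aromatic end, and the one step recorded there stayed within the scatter, so compound 4 gives the first reading at the oxygen next to a carbonyl group. In this assay oxolan-3-yl in place of isopropyl at this place gives a number 11 percentage points lower from compound 3 to compound 4 (beyond the scatter) and shows that the maximal response does respond to a change here, if only modestly. No evidence is available that would account for this step.

The single replacement brings in a ring, a ring oxygen and more heavy atoms all at once, so the compounds shown do not tell these apart. Going by these compounds, whether cyclopentyl, with the ring but no ring oxygen, or a 2-methoxyethyl chain, with the oxygen but no ring, would give a similar step on that oxygen stays open.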